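A few compounds are considered here, and "the series" means these few. Any claim that something is new, unique, unknown or untested is made for them only; others in the source may bear on it.

Compound 1 `COc1ccc(Cl)cc1C(=O)NCCC1CCN(S(=O)(=O)NC(=O)NC[C@@H]2C[C@@H]3C=C[C@@H]2C3)CC1`: 27%
Compound 2 `O=C(NC1CCCCC1)NS(=O)(=O)N1CCC(CCNC(=O)c2cc(Cl)cc3cccnc23)CC1`: 17%

In a functional assay on the whole organism (blood) with Rattus norvegicus as the target, with stated times of 24 h and 1 h, at a dose of 1 mg/kg by the intraperitoneal route (a higher number here means a stronger effect of the compound at the dose given, a lower number a weaker effect), compound 2 has the lowest of the two numbers, and its nearest neighbour, compound 1, lies within the usual scatter of it, so no order can be drawn between them. For the measured compounds named here, no step between measured compounds that differ in one place is available. Compound 3 `O=C(NC[C@@H]1C[C@@H]2C=C[C@@H]1C2)NS(=O)(=O)N1CCC(CCNC(=O)c2cc(Cl)cc3cccnc23)CC1` differs from compound 2 in one place: a group of 8 heavy atoms (8 carbon; 2 five-membered non-aromatic rings of carbon only) in place of a group of 6 heavy atoms (6 carbon; one six-membered non-aromatic ring of carbon only), on an amide-type nitrogen. Compound 1 carries that same entering group on another core and gives 27%. The step is expected to be an increase no larger than the scatter, a number 5 percentage points higher from compound 2 to compound 3 (within the scatter). Compound 3 is estimated at 22%, with a range from 8% to 38%.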

Compound 3, a percentage reported as activity, at one dose (the size of the read-out at that dose, not a potency): 16%
Compound 3: middle estimate off by 6 percentage points, on the high side; low and high end bracket the measured number.
By their numbers in this assay, from the lowest: compounds 3, 2 and 1 (each within the scatter of the next, the first and the last beyond it).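

In this assay, cyclohexyl on the amide-type nitrogen gives way to the group with two five-membered rings in a step of a number 1 percentage points lower from compound 2 to compound 3 (within the scatter), so this change does not separate the two compounds on their shared core. With that group held fixed, 6-chloroquinolin-8-yl in place of 5-chloro-2-methoxyphenyl on a carbonyl carbon gives a modest step of a number 11 percentage points lower from compound 1 to compound 3 (beyond the scatter), the only one here beyond the scatter. Nothing available explains either step. Going by these compounds, whether a phenyl or an open hexyl chain on that nitrogen would also leave the read-out unchanged remains open.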